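The source may hold more compounds than are shown below. What is called first, only, known or untested is meant among the compounds shown, and "the series" means these compounds.

Measured in a functional assay on HepG2 cells (Homo sapiens) for antiproliferative activity, read by XTT assay, with a stated time of 72 h; on this read-out higher numbers stand for weaker inhibition and lower numbers for stronger inhibition:
Compound 1 `CSc1ncnc2c1c(-c1ccoc1)cn2[C@@H]1O[C@H](CO)[C@@H](O)[C@H]1O`: > 15000 nM, a limit of the assay.
Compound 2 `CN(C)c1ncnc2c1c(-c1ccoc1)cn2[C@@H]1O[C@H](CO)[C@@H](O)[C@H]1O`: 12500 nM.
Compound 3 `Cc1ncnc2c1c(-c1ccoc1)cn2[C@@H]1O[C@H](CO)[C@@H](O)[C@H]1O`: 5320 nM.

Compound 3 gives the lowest number of the three, with a 2.3-fold lower number from compound 2 to compound 3 (0.37 log units; beyond the scatter) and an at least 2.8-fold lower number from compound 1 to compound 3 (0.45 log units; beyond the scatter). The remaining step, an at least 1.2-fold lower number from compound 1 to compound 2 (0.07 log units; that floor lies within the scatter), has a floor that lies within the scatter. All three steps exchange a group at a single aromatic carbon, and the furan-3-yl stays in place throughout.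

Compound 4 `Cc1ncnc2c1c(I)cn2[C@@H]1O[C@H](CO)[C@@H](O)[C@H]1O` departs from compound 3 at that furan-3-yl instead: iodo in place of furan-3-yl on an aromatic carbon. Among the measured compounds shown here, no measured step touches this place, so none gives a direct size for the exchange. For the measured compounds named here, the only guide is indirect: the one fully numerical step, a 2.3-fold lower number from compound 2 to compound 3 (0.37 log units; beyond the scatter), is modest, though it concerns a different group. Going by the values given here, the direction therefore stays open, and no step clearly beyond the scatter is firmly expected in this assay. The expected change is a 1.8-fold lower number from compound 3 to compound 4 (0.25 log units; within the scatter), and this estimate carries wide uncertainty. For compound 4 the estimated value is 3000 nM, with an expected range of 300 nM to 15000 nM.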

Compound 4, half-maximal inhibitory concentration: 3460 nM
For compound 4 the middle estimate is 1.2-fold (0.06 log units) below the measured one, within the range that was stated.
By their numbers in this assay, from the lowest: compounds 4 and 3 (each within the scatter of the next); then compound 2. At a limit, above all of these: compound 1.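

In this assay, the exchange of furan-3-yl for iodo gives a 1.5-fold lower number from compound 3 to compound 4 (0.19 log units; within the scatter) and so sizes a place that the steps among compound 1, compound 2 and compound 3 left untouched: an aromatic carbon of the five-membered aromatic ring with 1 nitrogen. Here a five-membered aromatic ring with 1 hetero atom gives way to a single iodine atom with no ring, yet the number stays within the scatter, whereas the exchange of dimethylamino for methyl at the other aromatic carbon gives a 2.3-fold lower number from compound 2 to compound 3 (0.37 log units; beyond the scatter) and lies beyond it. Nothing at hand gives a reason for this outcome at the new place.

As far as these compounds go, whether bromo, an amine, a carboxylic acid or a longer chain at this place would leave the number within the scatter of these two compounds stays open. From the compounds shown here alone, it is also open whether the exchange of furan-3-yl for iodo would give a step of similar size with methylsulfanyl or dimethylamino in place of the methyl group that compound 3 and compound 4 share.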